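The compounds below may be only part of what the source reports. "The series", "measured", "known", "first", "only" and "open" are said of these compounds alone.

The measured compounds:
compound 1, `Fc1ccc(-c2nc3cc(C(F)(F)F)ccc3[nH]2)cc1`, 22000 nM
compound 2, `CC(=O)Nc1ccc(-c2nc3ccccc3[nH]2)cc1`, 100000 nM
compound 3, `O=C(CN1CCCC1)Nc1ccc(-c2nc3cc(C(F)(F)F)ccc3[nH]2)cc1`, 18000 nM

Of the compounds shown here, three have been tested in an ADME assay on MT4 cells (Homo sapiens) for cytotoxicity, read by MTT assay, with a stated time of 96 h; on this read-out higher numbers stand for lower toxicity in this test and lower numbers for higher toxicity in this test. Compound 3 gives the lowest of the three numbers. Its nearest neighbour is compound 1, which gives 22000 nM, a gap that lies within the scatter; furthest away is compound 2, which gives 100000 nM, a gap beyond the scatter. Compound 4, `CC(=O)Nc1ccc(-c2nc3cc(C(F)(F)F)ccc3[nH]2)cc1`, has not yet been measured. It differs from compound 3 in one place: hydrogen in place of pyrrolidin-1-yl on a saturated chain carbon bound to a carbonyl carbon. Cut one bond further out, the change reads acetamido in place of (((pyrrolidin-1-yl)methyl)carbonyl)amino.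

Within the data shown here, one measured step bears on this change. Going from fluoro to (((pyrrolidin-1-yl)methyl)carbonyl)amino, the numbers show a 1.2-fold lower number from compound 1 to compound 3 (0.09 log units; within the scatter), so attaching the larger amide group on the shared core of compound 1 left this read-out essentially unchanged. Compound 2 carries the acetamido group that enters here, but on a core without trifluoromethyl, and no step between it and compound 4 is shown; compound 2 simply gives 100000 nM, the highest number in the set. Because a 1.2-fold lower number from compound 1 to compound 3 (0.09 log units; within the scatter) stayed within the scatter, the removal of pyrrolidin-1-yl is expected to shift the number in this assay only modestly, if at all, toward a higher value. Compound 4 is therefore expected to give about 30000 nM, with a range from 12000 nM to 75000 nM. This corresponds to an expected step of a 1.7-fold higher number from compound 3 to compound 4 (0.22 log units; within the scatter), not clearly beyond the scatter.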

Compound 4, half-maximal cytotoxic concentration: 19000 nM
Beside the measured number, compound 4's estimate is 1.6-fold (0.20 log units) above it; measured number inside the range.
By their numbers in this assay, from the lowest: compounds 3, 4 and 1 (each within the scatter of the next); then compound 2.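

In this assay, the pyrrolidin-1-yl group on the saturated chain carbon bound to a carbonyl carbon makes no readable difference: removing it and its 5 heavy atoms gives a 1.1-fold higher number from compound 3 to compound 4 (0.02 log units; within the scatter). Acetamido in place of fluoro on an aromatic carbon behaves alike, with a 1.2-fold lower number from compound 1 to compound 4 (0.06 log units; within the scatter), so on the shared core neither change separates compound 4 from its neighbours. Among these compounds, the one step beyond the scatter lies at another place, for trifluoromethyl in place of hydrogen on an aromatic carbon, with a 5.3-fold lower number from compound 2 to compound 4 (0.72 log units; beyond the scatter), which shows that the high number of compound 2 goes with the missing trifluoromethyl and not with its acetamido group.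

The compounds shown leave open whether a carboxylic acid, a piperidine or a longer chain on the same saturated chain carbon would also leave the number unchanged. They also leave open whether chloro or nitrile in place of trifluoromethyl on that aromatic carbon would give the same step, and no measurement at hand explains any of these steps.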